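Compound 1: 3-hydroxybenzyl to 3,4-dihydroxyphenyl

A few compounds are considered here, and "the series" means these few. Any claim that something is new, unique, unknown or untested is made for them only; others in the source may bear on it.

Compound 1 `O=C(NCCNS(=O)(=O)c1ccc(-c2ccccc2OCc2cccc(O)c2)s1)Nc1cc(C(F)(F)F)cc(C(F)(F)F)c1` reads 17300 nM as a number
Compound 2 `COc1ccc(Oc2ccc([N+](=O)[O-])cc2-c2ccsc2S(=O)(=O)N2CCN(C(=O)Nc3ccc([N+](=O)[O-])cc3)CC2)cc1OC` reads > 50000 nM as a limit
Compound 3 `O=C(NCCNS(=O)(=O)c1cc(-c2ccccc2Oc2ccc(O)c(O)c2)cs1)Nc1cc(Cl)cc(Cl)c1` reads > 50000 nM as a limit

For the measured compounds named here, in a functional assay on HeLa cells (Homo sapiens) for inhibition, read by CCK-8 assay, with a stated time of 48 h (a higher number here means a weaker inhibitor, a lower number a stronger inhibitor), compound 1 gives 17300 nM as the only number in the set. The remaining values stand at the limit of > 50000 nM in this assay, at which 2 of the 3 values shown sit, and carry no number of their own. Compound 4 `O=C(NCCNS(=O)(=O)c1ccc(-c2ccccc2Oc2ccc(O)c(O)c2)s1)Nc1cc(C(F)(F)F)cc(C(F)(F)F)c1` departs from compound 1 by one exchange (3,4-dihydroxyphenyl in place of 3-hydroxybenzyl on an oxygen on an aromatic ring). Going by the values given here, no measured pair isolates this exchange. Compound 3 also bears 3,4-dihydroxyphenyl and reads > 50000 nM as a limit. On that limit of compound 3 alone, the expected step (a 1.6-fold higher number from compound 1 to compound 4 (0.21 log units; within the scatter)) runs toward a weaker inhibitor. The estimate for compound 4 is 28000 nM with an expected range from 10000 nM to 70000 nM and a real chance of reaching the limit.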

Compound 4, half-maximal inhibitory concentration: > 20000 nM
Compound 4 gave a limit, no number; the forecaster's own chance of this, stated with the estimate: 40%; the middle value is on the limit's open side.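

In this assay the exchange of 3-hydroxybenzyl for 3,4-dihydroxyphenyl on the oxygen gives an at least 1.1-fold higher number from compound 1 to compound 4 (0.06 log units; that floor lies within the scatter) and so shows no gain at this position. Compound 4 stands at a limit, not a number: the limit of > 20000 nM in this assay, at which 1 of the 4 values shown sits. The size of any loss therefore cannot be read, and a change of no real size remains possible.

As far as these compounds go, the true value of compound 4 remains open, as does whether the hydroxyl groups matter individually. Also open, from the compounds shown here alone, is how a carboxylic acid or an amine on this aromatic ring would read in this assay.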